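Compound 2 to compound 4: hydrogen in place of methoxy

The source may report more compounds than this note shows. Statements on the series, on what has been measured and on what is new or still open speak of the compounds shown alone.

In a functional assay on cells (Homo sapiens) for antiproliferative activity, read by sulforhodamine B assay, with a stated time of 48 h (on this read-out higher numbers stand for weaker inhibition and lower numbers for stronger inhibition), three amides on a shared core differ only in the chain: compound 1 `CCCCCCCCNC(=O)[C@@H]1CSC(c2cc(OC)c(OC)c(OC)c2)N1` gives 17100 nM, compound 2 `CCCCCCCCCCCCNC(=O)[C@@H]1CSC(c2cc(OC)c(OC)c(OC)c2)N1` gives 2100 nM and compound 3 `CCCCCCCCCCCCCCNC(=O)[C@@H]1CSC(c2cc(OC)c(OC)c(OC)c2)N1` gives 2000 nM. Compound 2 therefore sits well under compound 1 and within the scatter of compound 3. The chain step an 8.1-fold lower number from compound 1 to compound 2 (0.91 log units; beyond the scatter) is modest and beyond the scatter, as is an 8.6-fold lower number from compound 1 to compound 3 (0.93 log units; beyond the scatter), whereas a 1.1-fold lower number from compound 2 to compound 3 (0.02 log units; within the scatter) stays within it.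

Compound 4 `CCCCCCCCCCCCNC(=O)[C@@H]1CSC(c2ccc(OC)c(OC)c2)N1` keeps the chain of compound 2 and changes the aromatic ring: hydrogen in place of methoxy on an aromatic carbon. In words, hydrogen replaces methoxy on an aromatic carbon. All three measured steps are chain steps, so none measures a change on the aromatic ring. They serve only as a rough guide to size, with an 8.1-fold lower number from compound 1 to compound 2 (0.91 log units; beyond the scatter) as the largest step seen. A small move towards a higher number in this assay is expected, quite possibly not beyond the scatter. The expected step is a 1.4-fold higher number from compound 2 to compound 4 (0.15 log units; within the scatter). For compound 4 the estimated value is 3000 nM. The estimated range for compound 4 runs from 1200 nM to 8000 nM.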

Compound 4, half-maximal inhibitory concentration: 2900 nM
Compound 4: the middle estimate sits 1.0-fold (0.01 log units) above what was measured, and the stated range covers the measured number.
By their numbers in this assay, from the lowest: compounds 3, 2 and 4 (each within the scatter of the next); then compound 1.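

In this assay, going by these compounds alone, a 1.4-fold higher number from compound 2 to compound 4 (0.14 log units; within the scatter) is the first measured step on the aromatic ring, as all earlier steps lay in the chain. At this aromatic carbon, ortho to a methoxy group, meta to a large group and meta to a methoxy group, hydrogen in place of methoxy stays within the scatter, so on the chain of compound 2 the read-out does not separate the compound that has this methoxy from the one that lacks it. No accompanying measurement bears on this result, and the reading stays purely a comparison of the two numbers.

Going by these compounds, whether the same replacement would also stay within the scatter on the chain of compound 1, or at either of the other two methoxy positions of the ring, remains open. Also open is how a different group at this same carbon, such as an amine, a carboxylic acid or a fluorine atom, would read in this assay, since hydrogen is the only replacement shown here.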